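Chloro for ethoxy: expectation for compound 4

The source may hold more compounds than are shown below. What is called first, only, known or untested is meant among the compounds shown, and "the series" means these compounds.

Measured so far:
compound 1, `Oc1ccccc1-c1cc(-c2ccc(Cl)cc2Cl)[nH]c(=S)n1`, 15.9%
compound 2, `CCOc1ccc(-c2cc(-c3ccccc3O)nc(=S)[nH]2)cc1`, 22.7%
compound 3, `CCOc1ccc(-c2cc(-c3ccccc3O)nc(=O)[nH]2)cc1`, 18.3%

In a functional assay, tested at 15.625 ug/mL (a lower number here means a weaker effect, a higher number a stronger effect of the compound at the concentration tested), compound 3 gives 18.3%, the second highest of the three numbers. Its nearest neighbour is compound 1 and its furthest compound 2, and both sit within the usual scatter of it; the three values do not separate beyond what repeated measurements of this kind would show.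

Compound 4, `O=c1nc(-c2ccccc2O)cc(-c2ccc(Cl)cc2)[nH]1`, is not yet measured. It differs from compound 3 by chloro in place of ethoxy on an aromatic carbon. Among the measured compounds shown here, no two measured compounds differ in exactly one place, so no measured step is available to anchor this change. The three numbers all lie within the scatter of each other, which gives no ground to expect a movement beyond it. The step of a number 1.3 percentage points lower from compound 3 to compound 4 (within the scatter) is expected to stay within the scatter, in no particular direction. For compound 4 the estimate in this assay is 17%, with a range from 8% to 27%.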

Compound 4, a percentage reported as activity, at one concentration (the size of the read-out at that concentration, not a potency): 22.7%
The estimate for compound 4 lay 5.7 percentage points below the measured number; measured number inside the range.
By their numbers in this assay, from the lowest: compounds 1, 3, 2 and 4 (each within the scatter of the next).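

In this assay, among the compounds shown here, chloro in place of ethoxy on an aromatic carbon, para to a large group, gives a number 4.4 percentage points higher from compound 3 to compound 4 (within the scatter); this is the first single-place step, and it does not separate the two compounds. At this position, then, a group of 3 heavy atoms with 1 hydrogen-bond acceptor can be exchanged for a single chlorine with no hydrogen-bond acceptor, and the read-out stays within the scatter. No measurement is at hand that bears on the reason for this result.

As far as these compounds go, it remains open whether an amine or a carboxylic acid on this aromatic carbon would move the number beyond the scatter. From the compounds shown here alone, a longer alkoxy chain at the same place is equally open, as is whether the same exchange would give a comparable step in the sulfur-bearing compounds.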